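A few compounds are considered here, and "the series" means these few. Any claim that something is new, unique, unknown or untested is made for them only; others in the source may bear on it.

Compound 3 `CCCC(C)n1c(CC)nc2c(-c3ccc(C(F)(F)F)cc3Cl)nccc21` gives 3.5 nM in an assay for binding affinity to Corticotropin releasing factor receptor (Rattus norvegicus); a lower number here means a stronger inhibitor, a higher number a weaker inhibitor. Compound 1 `CCCC(C)n1c(CC)nc2c(-c3ccc(OC(F)(F)F)cc3Cl)nccc21` gives 2.8 nM in this assay, and compound 2 `CCc1nc2c(-c3ccc(C(F)(F)F)cc3Cl)nccc2n1C(CC)CC` gives 5.4 nM. The step of a 1.3-fold higher number from compound 1 to compound 3 (0.10 log units; within the scatter) exchanges the substituent on the aromatic ring; the step of a 1.5-fold lower number from compound 2 to compound 3 (0.19 log units; within the scatter) exchanges the group on the aromatic nitrogen. Compound 3 therefore sits second highest of the three numbers, but all three lie within the usual scatter of one another, so no order among them can be drawn.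

Compound 4 `CCc1nc2c(-c3ccc(C(F)(F)F)cc3Cl)nccc2n1C(CC)C1CC1` differs from compound 3 in one place: 1-cyclopropylpropyl in place of 1-methylbutyl on an aromatic nitrogen. For the measured compounds named here, the only measured step that bears on this position is a 1.5-fold lower number from compound 2 to compound 3 (0.19 log units; within the scatter), a change of the group on the aromatic nitrogen that stayed within the scatter. On this basis no step beyond the scatter is expected in this assay, and the step of no change at the digits printed from compound 3 to compound 4 (within the scatter) is the estimate. Compound 4 is expected to give about 3.5 nM, with a range from 1.5 nM to 8 nM.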

Compound 4, inhibition constant: 2.9 nM
The estimate for compound 4 lay 1.2-fold (0.08 log units) above the measured number, and the stated range covers the measured number.
By their numbers in this assay, from the lowest: compounds 1, 4, 3 and 2 (each within the scatter of the next).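

The group on the aromatic nitrogen can now carry a ring without a step beyond the scatter: in this assay, 1-cyclopropylpropyl in place of 1-methylbutyl gives a 1.2-fold lower number from compound 3 to compound 4 (0.08 log units; within the scatter), and cyclopropyl in place of ethyl on the saturated chain carbon bound to that nitrogen gives a 1.9-fold lower number from compound 2 to compound 4 (0.27 log units; within the scatter). For the compounds shown here, the open-chain groups of the earlier compounds are therefore not the only ones at this position that give numbers of this size, although the step from compound 2 is the largest read here and still does not separate the two compounds. No supporting data bear on this result.

On these data alone, it remains open whether this position keeps such numbers with a longer chain, a cyclohexyl ring or an amine on the group. As far as these compounds go, the pairing of 1-cyclopropylpropyl with the trifluoromethoxy of compound 1 also remains open.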